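The compounds below may be only part of what the source reports. "The series", "measured", "known", "first", "only" and "open" are said of these compounds alone.

Measured compounds in a functional assay on HeLa cells (Homo sapiens) for cytotoxicity, read by CCK-8 assay, with a stated time of 72 h; on this read-out higher numbers stand for weaker inhibition and lower numbers for stronger inhibition:
- compound 1, `C=CCn1c(=O)/c(=C\c2cccc(C)c2)[nH]c(=O)/c1=C\c1ccccc1OC`: 19300 nM
- compound 2, `COc1ccccc1/C=c1/[nH]c(=O)/c(=C\c2ccccc2OC)[nH]c1=O`: "not active" (no number reported)
- compound 3, `COc1ccccc1/C=c1\c(=O)[nH]/c(=C/c2cccc(Cl)c2Cl)c(=O)n1C`: 200 nM

Compound 1 gives the highest of the two numbers in this assay. Its nearest neighbour in value is compound 3, which lies well below it, a gap beyond the scatter. Compound 2 gives no number at all, being reported as not active. No two of these compounds differ in one place only, so no measured step exists to guide the next estimate.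

Compound 4, `C=CCn1c(=O)/c(=C\c2cc(F)ccc2C)[nH]c(=O)/c1=C\c1ccccc1OC`, is not yet measured in this assay. It differs from compound 1 in one place: 5-fluoro-2-methylphenyl in place of 3-methylphenyl on a double-bonded chain carbon bound to an aromatic carbon. The other part of the shared core, with the allyl group and the methoxyphenyl, is kept unchanged. For the measured compounds named here, with no measured step of this kind to draw on, compound 4 is expected to stay close to compound 1, with a step of a 1.3-fold lower number from compound 1 to compound 4 (0.11 log units; within the scatter) that is not expected to go beyond the scatter in either direction. Compound 4 is therefore estimated at 15000 nM, in a range from 5000 nM to 45000 nM.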

Compound 4, half-maximal inhibitory concentration: 2900 nM
Estimate against measurement, compound 4: 5.2-fold (0.71 log units) above, and the stated range ends above it.
By their numbers in this assay, from the lowest: compound 3; then compound 4; then compound 1.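

In this assay, for the compounds shown here, the step of a 6.7-fold lower number from compound 1 to compound 4 (0.82 log units; beyond the scatter) is the first single-place comparison in this set, and it shows that the aryl group on a double-bonded chain carbon bound to an aromatic carbon can shift the read-out while the allyl group and the methoxyphenyl stay unchanged. The change from 3-methylphenyl to 5-fluoro-2-methylphenyl adds one fluorine and alters the place of the methyl, with no hydrogen-bond donor or acceptor on either side. No measurement here accounts for this shift.

As far as these compounds go, whether the fluorine or the changed place of the methyl carries the step remains open. Also open, from the compounds shown here alone, is how this position would respond to a plain 2-methylphenyl group, or to a phenyl ring bearing an amine.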